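The compounds below may be only part of what the source reports. "The series", "measured", "known", "first", "only" and "open" are said of these compounds alone.

Measured compounds:
Compound 1, `COC(=O)[C@@]1(C)C[C@@H](c2coc3ccc(F)cc3c2=O)N(c2ccccc2)O1`, gave 31300 nM in a functional assay on PC-3 cells (Homo sapiens) for inhibition, read by sulforhodamine B assay, with a stated time of 48 h; a higher number here means a weaker inhibitor, a lower number a stronger inhibitor.
Compound 2, `O=c1c([C@@H]2C[C@H](c3ccccc3)ON2c2ccccc2)coc2cc(Cl)c(Cl)cc12`, gave 32000 nM in this assay.
Compound 3, `O=c1c([C@@H]2C[C@H](c3ccccc3)ON2c2ccccc2)coc2ccccc12`, reached only a limit of > 60000 nM in this assay, which is a limit and not a number.

Compound 1 has the lowest of the two numbers, but compound 2 sits within the scatter of it, so no order between the two can be drawn. Compound 3 sits at the limit of > 60000 nM in this assay, at which 1 of the 3 values shown sits. Compound 4, `COC(=O)[C@@]1(C)C[C@@H](c2coc3ccc(Br)cc3c2=O)N(c2ccccc2)O1`, has not yet been tested in this assay. It differs from compound 1 by bromo in place of fluoro on an aromatic carbon. For the measured compounds named here, no step between measured compounds covers this change, so nothing beyond the scatter is expected in this assay, in either direction. Compound 4 is expected to give 25000 nM, with a range from 10000 nM to 60000 nM. The expected step is a 1.3-fold lower number from compound 1 to compound 4 (0.10 log units; within the scatter).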

Compound 4, half-maximal inhibitory concentration: > 60000 nM
Compound 4: a limit, no number (the forecaster's own chance of this, stated with the estimate: 20%); at least 2.4-fold (0.38 log units) between middle value and limit.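

In this assay, for the compounds shown here, the change at this aromatic carbon gives the first step between compounds differing in one place: an at least 1.9-fold higher number from compound 1 to compound 4 (0.28 log units; that floor lies within the scatter). That floor lies within the scatter, so the true size of the step cannot be read, but bromo in place of fluoro brings no lower number here. Compound 4 gives a limit and not a number: the limit of > 60000 nM in this assay, at which 2 of the 4 values shown sit.

The compounds shown leave open whether an amine or a methoxy group on this aromatic carbon would give a number in this assay. They also leave open how a carboxylic acid in place of the methyl ester of compound 1 would read.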